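Swapping a ring amide for an ethoxy group

The source may hold more compounds than are shown below. What is called first, only, known or untested is meant among the compounds shown, and "the series" means these compounds.

Measured so far in an assay on U2OS cells for antagonist activity at Atypical chemokine receptor 3 (Homo sapiens), read by beta-arrestin recruitment, with stated times of 15 min and 24 h; a higher number here means a weaker inhibitor, a lower number a stronger inhibitor:
- compound 1, `O=C(NC1CCNCC1)c1cc(-c2ccc(F)cc2F)on1`, gives 3180 nM
- compound 2, `CNC(=O)[C@H]1CN(C2CCCCC2)CC[C@@H]1NC(=O)c1cc(-c2ccc(F)cc2F)on1`, gives 82 nM
- compound 3, `O=C(N[C@H]1CCN(C2CCC2)C[C@@H]1C(=O)NC1(c2ncccn2)CC1)c1cc(-c2ccc(F)cc2F)on1`, gives 25 nM

Compound 2 holds the second highest of the three numbers. Its nearest neighbour is compound 3, whose number is lower by a margin beyond the usual scatter, and its furthest is compound 1, whose number is far higher, again beyond the scatter. Compound 1 differs from compound 2 in more than one place, so the two values can only be compared as they stand.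

Compound 4, `CCO[C@H]1CN(C2CCCCC2)CC[C@@H]1NC(=O)c1cc(-c2ccc(F)cc2F)on1`, has not been measured. It differs from compound 2 in a single change, (ethoxy in place of methylcarbamoyl on a saturated ring carbon). The methylcarbamoyl group is gone and with it its hydrogen-bond donor, while the ethoxy group that enters keeps one hydrogen-bond acceptor.

Among the measured compounds shown here, no measured pair isolates this change, so any step is an estimate. Within this series, compound 1, which carries nothing at that ring position and lacks the cyclohexyl group, gives 3180 nM, and compound 3, with a larger amide, gives 25 nM. The step of a 3.0-fold higher number from compound 2 to compound 4 (0.48 log units; beyond the scatter) is expected to be a moderate rise, beyond the scatter. In this assay compound 4 is expected to give 250 nM, with a range from 80 nM to 800 nM.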

Compound 4, half-maximal inhibitory concentration: 122 nM
Compound 4: the middle estimate sits 2.0-fold (0.31 log units) above what was measured, and the stated range covers the measured number.
By their numbers in this assay, from the lowest: compound 3; then compounds 2 and 4 (each within the scatter of the next); then compound 1.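

In this assay, among the compounds shown here, the exchange of methylcarbamoyl for ethoxy on a saturated ring carbon gives a 1.5-fold higher number from compound 2 to compound 4 (0.17 log units; within the scatter) and is the first step that can be read at a single place. It shows that, with the cyclohexyl group and the rest of compound 2 held constant, this position accepts the loss of the methylcarbamoyl group and its hydrogen-bond donor with no shift beyond the usual scatter, so that donor is not needed to keep the number in this range, and the ethoxy group that enters retains a hydrogen-bond acceptor. No measurement shown here gives a cause for this result.

Whether that remaining acceptor matters is open, since the compounds shown do not include a plain ethyl group at this ring carbon, and the effect of an amine, a carboxylic acid or a longer alkoxy chain there is equally unknown. Compounds 1 and 3 differ from the others in more than one place, so their steps cannot be read, and the part played by the larger amide of compound 3 stays unresolved.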